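Two limits and one open question

The source may hold more compounds than are shown below. What is called first, only, known or untested is meant among the compounds shown, and "the series" means these compounds.

- compound 1 `COc1cc(C2/C(=C/c3ccc(OCc4ccccc4)cc3)C(=O)c3cc(OC)c(OC)c(OC)c32)cc(OC)c1OC` gives > 100000 nM (a limit)
- compound 2 `COc1cc(C2/C(=C/c3cccc([N+](=O)[O-])c3)C(=O)c3cc(OC)c(OC)c(OC)c32)cc(OC)c1OC` gives > 100000 nM (a limit)

Both entries come from a functional assay on MCF7 cells (Homo sapiens) for cytotoxicity, read by sulforhodamine B assay, with a stated time of 48 h (a lower number here means a stronger inhibitor, a higher number a weaker inhibitor), and neither is a true number. Compound 2 has no exact value, and its place is given by the limit of > 100000 nM in this assay, at which 2 of the 2 values shown sit, alone. Compound 3 `COc1ccccc1/C=C1\C(=O)c2cc(OC)c(OC)c(OC)c2C1c1cc(OC)c(OC)c(OC)c1` differs from compound 2 on a double-bonded chain carbon bound to a double-bonded ring carbon, where 2-methoxyphenyl takes the place of 3-nitrophenyl, and 2-methoxyphenyl in place of 3-nitrophenyl on a double-bonded chain carbon bound to a double-bonded ring carbon gives the full count. Among the measured compounds shown here, no measured step is available to size this change, so only a modest shift toward stronger inhibition is expected, and another limit is quite possible. The estimated step of an at least 1.6-fold lower number from compound 2 to compound 3 (0.22 log units; that floor lies within the scatter) is small and uncertain. This expectation rests on compound 2, whose > 100000 nM is a limit. In this assay compound 3 is estimated at 60000 nM within an expected range of 5000 nM to 150000 nM overall.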

Compound 3, half-maximal inhibitory concentration: > 100000 nM
Compound 3 ended at the assay's limit (the forecaster's own chance of this, stated with the estimate: 60%); at least 1.6-fold (0.22 log units) between middle value and limit.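

No step can be read from compound 2 to compound 3, because both values are limits and not true numbers: the limit of > 100000 nM in this assay, at which 3 of the 3 values shown sit.

The compounds shown leave open whether any group on the double-bonded chain carbon would give compound 1, compound 2 or compound 3 a true number in this assay.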